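Chlorobenzyl for methylbenzyl on two related cores

A few compounds are considered here, and "the series" means these few. Any claim that something is new, unique, unknown or untested is made for them only; others in the source may bear on it.

Measured compounds:
Compound 1, `Cc1ccc(COc2ccc(-c3nn(CCC#N)c(=O)o3)cc2)cc1`: 25000 nM
Compound 2, `N#CCCn1nc(-c2ccc(OCc3cccc(Cl)c3)cc2)oc1=O`: 7400 nM
Compound 3, `Cc1ccc(COc2ccc(C3=NN(CCC#N)C(=O)CO3)cc2)cc1`: 250000 nM

The study covers a pair of cores carrying a benzyloxyphenyl group. In an assay for inhibition of Amine oxidase [flavin-containing] A (Rattus norvegicus) (on this read-out lower numbers stand for stronger inhibition and higher numbers for weaker inhibition), compound 1 gives 25000 nM and compound 2 gives 7400 nM. The step between them, (3-chlorophenyl in place of 4-methylphenyl on a saturated chain carbon bound to an oxygen on an aromatic ring), brought a 3.4-fold lower number from compound 1 to compound 2 (0.53 log units; beyond the scatter). Compound 3 holds the other core; in this assay compound 3 gives 250000 nM, the highest number of the three. The difference between the two cores, that of compound 1 and compound 3, is not broken down here.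

Compound 4, `N#CCCN1N=C(c2ccc(OCc3cccc(Cl)c3)cc2)OCC1=O`, has not yet been measured. It differs from compound 3 by 3-chlorophenyl in place of 4-methylphenyl on a saturated chain carbon bound to an oxygen on an aromatic ring, the same change that took compound 1 to compound 2; the place is the same in both cases. Because a 3.4-fold lower number from compound 1 to compound 2 (0.53 log units; beyond the scatter) was seen on the core of compound 1, a step of similar size is expected on the core of compound 3, with the caution that this rests on a single earlier pair. The step from compound 3 to compound 4 is estimated as a 3.3-fold lower number from compound 3 to compound 4 (0.52 log units; beyond the scatter). For compound 4 the expected value in this assay is 75000 nM, between 25000 nM and 250000 nM.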

Compound 4, half-maximal inhibitory concentration: 13000 nM
Compound 4: middle estimate off by 5.8-fold (0.76 log units), on the high side; measured number outside the range, below it.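

In this assay, 3-chlorophenyl in place of 4-methylphenyl brought a 19-fold lower number from compound 3 to compound 4 (1.28 log units; beyond the scatter), so the number fell on both cores, but the size of the step did not carry over from one core to the other: the same change on two cores in this assay, a 3.4-fold lower number (0.53 log units; beyond the scatter) from compound 1 to compound 2 and a 19-fold lower number (1.28 log units; beyond the scatter) from compound 3 to compound 4, 5.7-fold (0.76 log units) apart, beyond the scatter of two such steps

The direction of the change therefore held on the core of compound 1 and on the core of compound 3, while its size cannot be taken from one core and applied to the other. With a single pair on each core, this does not show why the two steps differ, or how the change would behave on a third core.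

The compounds shown leave open how far the chlorine and how far the loss of the methyl group each account for the two steps, a question that an unsubstituted phenyl group on each core would bear on. They also leave open whether the gap between the steps would persist with an amine or a carboxylic acid in place of the nitrile.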